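Moving the bromo group: compound 3 to compound 4

The source may report more compounds than this note shows. Statements on the series, on what has been measured and on what is new or still open speak of the compounds shown alone.

Measured in a functional assay on HepG2 cells (Homo sapiens) for antiproliferative activity, read by MTT assay, with a stated time of 48 h; on this read-out lower numbers stand for stronger inhibition and higher numbers for weaker inhibition:
- compound 1 `CC(=O)N1N=C(c2ccc3ccccc3c2)OC1c1ccccc1` gives 2.11 ug/mL
- compound 2 `COc1ccc(C2OC(c3ccc4ccccc4c3)=NN2C(C)=O)cc1` gives 3.6 ug/mL
- compound 3 `CC(=O)N1N=C(c2ccc3ccccc3c2)OC1c1ccccc1Br` gives 3.98 ug/mL

The steps of a 1.9-fold higher number from compound 1 to compound 3 (0.28 log units; within the scatter) and a 1.1-fold higher number from compound 2 to compound 3 (0.04 log units; within the scatter) leave compound 3 without a clear rank among the three. Compound 4 `CC(=O)N1N=C(c2ccc3ccccc3c2)OC1c1cccc(Br)c1` has 3-bromophenyl in place of 2-bromophenyl on a saturated ring carbon, with 3-bromophenyl in place of 2-bromophenyl on a saturated ring carbon as the counted difference. Among the measured compounds shown here, no measured compound carries 3-bromophenyl. The nearest evidence is those two steps on the same carbon, along with a 1.7-fold higher number from compound 1 to compound 2 (0.23 log units; within the scatter) for the aryl substituent, so no step beyond the scatter is expected in this assay. The expected change is a 1.3-fold lower number from compound 3 to compound 4 (0.12 log units; within the scatter) and no more. For compound 4 the estimated value is 3 ug/mL with an expected range from 1.6 ug/mL to 5.6 ug/mL in this read-out.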

Compound 4, half-maximal inhibitory concentration: 1.68 ug/mL
Beside the measured number, compound 4's estimate is 1.8-fold (0.25 log units) above it; the range from low to high includes it.
By their numbers in this assay, from the lowest: compounds 4, 1, 2 and 3 (each within the scatter of the next, the first and the last beyond it).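

In this assay, among the compounds shown here, the placement of the bromo group on the phenyl ring at this saturated ring carbon gives the first step beyond the scatter (a 2.4-fold lower number from compound 3 to compound 4 (0.37 log units; beyond the scatter)). The 3-bromophenyl group also separates from 4-methoxyphenyl (a 2.1-fold lower number from compound 2 to compound 4 (0.33 log units; beyond the scatter)) but not from unsubstituted phenyl, where bromo in place of hydrogen stays within the scatter (a 1.3-fold lower number from compound 1 to compound 4 (0.10 log units; within the scatter)). Nothing at hand explains these steps.

Still open, as far as these compounds go, is whether 3-chlorophenyl or 3-aminophenyl would match 3-bromophenyl on this carbon. Also open, from the compounds shown here alone, is whether a longer acyl chain in place of the acetyl group would shift the number.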